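The source may hold more compounds than are shown below. What is called first, only, known or untested is meant among the compounds shown, and "the series" means these compounds.

Values measured in an ADME assay on MDCK cells (Canis lupus familiaris) for permeability, read by LC-MS, in the apical to basolateral direction; on this read-out higher numbers stand for higher permeability and lower numbers for lower permeability:
- compound 1 `C[C@H](N/C(=N\S(=O)(=O)c1ccc(Cl)cc1)N1CC(c2ccccc2)C(c2ccc(Cl)cc2)=N1)C(N)=O` gives 2.44 10^-6 cm/s
- compound 2 `NC(=O)CNC(=O)CN/C(=N\S(=O)(=O)c1ccc(Cl)cc1)N1CC(c2ccccc2)C(c2ccc(Cl)cc2)=N1` gives 1.8 10^-6 cm/s

Within the data shown here, compound 2 has only one measured neighbour, and the two values lie within the scatter of each other. Among the measured compounds shown here, the single measured step is a 1.4-fold lower number from compound 1 to compound 2 (0.13 log units; within the scatter).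

Compound 3 `CC(C)(C)[C@H](N/C(=N\S(=O)(=O)c1ccc(Cl)cc1)N1CC(c2ccccc2)C(c2ccc(Cl)cc2)=N1)C(N)=O` has not yet been measured. It carries 1-carbamoyl-2,2-dimethylpropyl in place of ((carbamoylmethyl)carbamoyl)methyl on an amine nitrogen.

For the measured compounds named here, only the step to compound 2 bears on this change, as it involves the same ((carbamoylmethyl)carbamoyl)methyl group, set against 1-carbamoylethyl. Going by the values given here, no measured compound carries 1-carbamoyl-2,2-dimethylpropyl, so the evidence is indirect. With that one small step as the guide, no change beyond the scatter is expected in this assay. A slight upward lean is expected, resting weakly on compound 1 at 2.44 10^-6 cm/s, which also lacks the group that leaves. The expected change is a 1.6-fold higher number from compound 2 to compound 3 (0.19 log units; within the scatter). For compound 3 the estimated value is 2.8 10^-6 cm/s, with an expected range from 1.2 10^-6 cm/s to 6.5 10^-6 cm/s.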

Compound 3, apparent permeability: 0.7 10^-6 cm/s
For compound 3 the middle estimate is 4.0-fold (0.60 log units) above the measured one; the whole stated range lies above it.
By their numbers in this assay, from the lowest: compound 3; then compounds 2 and 1 (each within the scatter of the next).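

In this assay this position turned out to be able to move the number beyond the scatter: the exchange gives a 2.6-fold lower number from compound 2 to compound 3 (0.41 log units; beyond the scatter), whereas the earlier step, a 1.4-fold lower number from compound 1 to compound 2 (0.13 log units; within the scatter), stayed within it. Among these compounds, the closer pair adds that tert-butyl in place of methyl on a saturated chain carbon bound to an amine nitrogen and a carbonyl carbon is enough on its own, giving a 3.5-fold lower number from compound 1 to compound 3 (0.54 log units; beyond the scatter), even though the group entering in compound 3 counts fewer hydrogen-bond donors and acceptors than the one leaving compound 2. The data shown contain no separate measurement that would account for this fall.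

From the compounds shown here alone, it remains open whether smaller branched groups such as isopropyl or isobutyl would keep the number near that of compound 1 or already bring it down towards that of compound 3. Going by these compounds, it is equally open how a carboxylic acid or a primary amine in place of the carbamoyl group, or the opposite configuration at the defined stereocentre of compound 3, would read in this assay.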